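Chloro for Bromo: What to Expect of Compound 4

A few compounds are considered here, and "the series" means these few. Any claim that something is new, unique, unknown or untested is made for them only; others in the source may bear on it.

Measured so far in a functional assay on HBL-100 cells (Homo sapiens) for inhibition, read by sulforhodamine B assay, with a stated time of 48 h; a lower number here means a stronger inhibitor of growth, a higher number a weaker inhibitor of growth:
compound 1, `COC(=O)[C@@]1(C)CCC=C2[C@@H]1CC[C@@H](C)[C@]2(C)Cc1c[nH]c2ccc(Br)cc12`, compound 1 gives 16000 nM
compound 2, `COC(=O)[C@@]1(C)CCC=C2[C@@H]1CC[C@@H](C)[C@]2(C)Cc1c[nH]c2ccc(Cl)cc12`, compound 2 gives 17000 nM
compound 3, `COC(=O)[C@@]1(C)CCC=C2[C@@H]1CC[C@@H](C)[C@]2(C)Cc1c(C)[nH]c2ccc(Br)cc12`, compound 3 gives 15000 nM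

Three compounds share one core and differ only at two places. Compound 1 and compound 2 differ by chloro in place of bromo on an aromatic carbon, and that change made a 1.1-fold higher number from compound 1 to compound 2 (0.03 log units; within the scatter). Compound 1 and compound 3 differ by methyl in place of hydrogen on an aromatic carbon, with a 1.1-fold lower number from compound 1 to compound 3 (0.03 log units; within the scatter). The three values thus lie close together, and none can be called stronger or weaker than another.

Compound 4, `COC(=O)[C@@]1(C)CCC=C2[C@@H]1CC[C@@H](C)[C@]2(C)Cc1c(C)[nH]c2ccc(Cl)cc12`, is not yet measured. Compound 4 differs from compound 3 by chloro in place of bromo on an aromatic carbon, the same kind of change as from compound 1 to compound 2, placed in the same words. Since that earlier step from compound 1 to compound 2 gave a 1.1-fold higher number from compound 1 to compound 2 (0.03 log units; within the scatter), the step from compound 3 to compound 4 is expected to be of similar size, about a 1.1-fold higher number from compound 3 to compound 4 (0.03 log units; within the scatter) in this assay. Compound 4 is therefore estimated at 16000 nM, plausibly between 9000 nM and 28000 nM.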

Compound 4, concentration for 50% growth inhibition: 15000 nM
The estimate for compound 4 lay 1.1-fold (0.03 log units) above the measured number, and the stated range covers the measured number.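

In this assay, among the compounds shown here, chloro in place of bromo on an aromatic carbon gave no change at the digits printed from compound 3 to compound 4 (within the scatter), and the two cores agree on this change: the same change on two cores in this assay, a 1.1-fold higher number (0.03 log units; within the scatter) from compound 1 to compound 2 and no change at the digits printed (within the scatter) from compound 3 to compound 4, 1.1-fold (0.03 log units) apart, within the scatter of two such steps Methyl in place of hydrogen on an aromatic carbon gave a 1.1-fold lower number from compound 2 to compound 4 (0.05 log units; within the scatter), and here too the two cores agree: the same change on two cores in this assay, a 1.1-fold lower number (0.03 log units; within the scatter) from compound 1 to compound 3 and a 1.1-fold lower number (0.05 log units; within the scatter) from compound 2 to compound 4, 1.1-fold (0.03 log units) apart, within the scatter of two such steps This shows that neither change moved the number beyond the scatter on either core, but with no step of measurable size there is no real effect to carry across, so the agreement does not show that a larger effect would transfer from one core to another, and it rests on only two cores in a single assay.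

The compounds shown leave open whether the growth-inhibition number responds at all to a more distinct group in place of the halogen, such as an amine, a nitrile or a methoxy group. They also leave open what a longer chain in place of the methyl group, or a carboxylic acid in place of the methyl ester, would do.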